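This account rests on a few compounds, and the source may have more. Where it says the series, first, only, none or still open, it means among the compounds named here.

Measured compounds in this series:
compound 1 `Cc1nnsc1CO/N=C/c1c(C)nn(C)c1Oc1ccc(F)cc1`; in a functional assay on PANC-1 cells (Homo sapiens) for inhibition, read by MTT assay, with a stated time of 48 h (on this read-out higher numbers stand for weaker inhibition and lower numbers for stronger inhibition), compound 1 gives > 50000 nM, which is a limit of the assay and not a number.
compound 2 `Cc1cccc(Oc2c(/C=N/OCc3snnc3C)c(C)nn2C)c1`; in this assay compound 2 gives > 50000 nM, also a limit.
compound 3 `Cc1nnsc1CO/N=C/c1c(C)nn(C)c1Oc1cccc(F)c1F`; in this assay compound 3 gives 12200 nM.

Compound 1 therefore stands at the floor of what this series shows: it sits at the limit of > 50000 nM in this assay, at which 2 of the 3 values shown sit, together with compound 2, and only compound 3 carries a read number. The steps that are readable all change the aryl group on the oxygen: an at least 4.0-fold lower number from compound 1 to compound 3 (0.61 log units; beyond the scatter) and an at least 4.0-fold lower number from compound 2 to compound 3 (0.61 log units; beyond the scatter), while a step that the two limits leave unreadable from compound 1 to compound 2.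

The step to compound 4 `CCCc1nnsc1CO/N=C/c1c(C)nn(C)c1Oc1ccc(F)cc1` changes a different place. Relative to compound 1 it reads: ethyl in place of hydrogen on a saturated chain carbon bound to an aromatic carbon. The aryl group on the oxygen is kept as in compound 1. Among the measured compounds shown here, none of the measured steps touches the group on the thiadiazole, so no measured step bears on this change, and nothing argues for a movement in either direction beyond the scatter.

With compound 1 at a limit in this assay, compound 4 is expected to remain near that limit, an estimated 60000 nM with a range of 15000 nM to 200000 nM. The step from compound 1 to compound 4 is thus expected to be a step that the limit leaves unreadable from compound 1 to compound 4, most likely reported again only as a limit.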

Compound 4, half-maximal inhibitory concentration: > 50000 nM
Compound 4 was reported as a limit; the forecaster's own chance of this, stated with the estimate: 70%; the middle value lies beyond the limit too.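

In this assay compound 1 and compound 4 both stand only as limits, so no step between them can be read, and the series mostly rests at one limit: the limit of > 50000 nM in this assay, at which 3 of the 4 values shown sit.

Still open, from the compounds shown here alone, is whether 4-propyl-1,2,3-thiadiazol-5-yl in place of 4-methyl-1,2,3-thiadiazol-5-yl shifts the read-out when the aryl group on the oxygen is that of compound 3, which carries a read number.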